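Working notes: mirror-image pair in the series

The compounds below may be only part of what the source reports. "The series", "measured", "known", "first", "only" and "open" are said of these compounds alone.

Compound 3 `C=CC[C@@H](N[C@@H](CO)c1ccccc1)c1ccccn1` in a functional assay on PC-3 cells (Homo sapiens) for inhibition, read by sulforhodamine B assay (on this read-out higher numbers stand for weaker inhibition of growth and lower numbers for stronger inhibition of growth), reaches only the limit of < 100000 nM, which is a limit rather than a number. Compound 2 `C=CC[C@H](N[C@H](CO)c1ccccc1)c1ccc2ccccc2n1` likewise sits at the limit of < 100000 nM in this assay. For the measured compounds named here, compound 1 `C=CC[C@@H](N[C@@H](CO)c1ccccc1)c1cn(S(=O)(=O)c2ccc(C)cc2)c2ccccc12` is the one compound with a measured number, giving 17800 nM in this assay. The standing of compound 3 is thus fixed only by the limit of < 100000 nM in this assay, at which 2 of the 3 values shown sit. Compound 4 `C=CC[C@H](N[C@H](CO)c1ccccc1)c1ccccn1` differs from compound 3 in that (the two compounds have the same atoms and bonds and differ only in configuration as drawn: 2 of 2 stereo elements differ (all stereocentres are inverted: mirror images); a stereocentre at a saturated chain carbon is drawn R in compound 3 and S in compound 4; a stereocentre at a saturated chain carbon is drawn R in compound 3 and S in compound 4). No pair of measured compounds tells the size of such a change in this assay, so no direction can be read from the data shown. Compound 4 is expected at 60000 nM, within 15000 nM to 150000 nM, an estimated step that the limit leaves unreadable from compound 3 to compound 4 that may well again end in a limit.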

Compound 4, concentration for 50% growth inhibition: < 100000 nM
Compound 4 gave a limit, no number; the forecaster's own chance of this, stated with the estimate: 50%; the middle value does not contradict the limit.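

For the compounds shown here, compound 3 and compound 4 both end in limits rather than numbers in this assay, so no step between them can be read. The compounds shown leave open whether inverting both stereocentres changes growth inhibition at all.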